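The source may report more compounds than this note shows. Statements on the series, on what has been measured and on what is new or still open speak of the compounds shown alone.

- Compound 1 `COc1cc(NC(=O)NNc2cc(-c3ccccc3)c3cnn(C)c3n2)cc(Cl)n1` gives 31300 nM
- Compound 2 `Cn1ncc2c(-c3ccc(F)cc3)cc(NNC(=O)Nc3cc(Cl)nc(OCCF)c3)nc21` gives 37200 nM

In a functional assay on HCT-116 cells (Homo sapiens) for cytotoxicity, read by MTT assay, with a stated time of 48 h, in the presence of a further agent that is not named here (a lower number here means that less compound is needed, a higher number that more compound is needed for the effect), compound 2 stands at 37200 nM, within the scatter of compound 1 at 31300 nM. Compound 3 `COc1cc(NC(=O)NNc2cc(-c3ccc(F)cc3)c3cnn(C)c3n2)cc(Cl)n1` departs from compound 2 in one place: hydrogen in place of fluoromethyl on a saturated chain carbon bound to an oxygen on an aromatic ring, turning 2-fluoroethoxy into methoxy. Among the compounds with values here, no measured pair shows this change on its own, so no step beyond the scatter is expected in this assay. The expected step is a 1.1-fold lower number from compound 2 to compound 3 (0.05 log units; within the scatter). The estimate for compound 3 is 33000 nM, with an expected range from 15000 nM to 70000 nM.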

Compound 3, half-maximal effective concentration: 75300 nM
Compound 3: middle estimate off by 2.3-fold (0.36 log units), on the low side; the whole stated range lies below it.
By their numbers in this assay, from the lowest: compounds 1 and 2 (each within the scatter of the next); then compound 3.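

In this assay, turning 2-fluoroethoxy into methoxy gives a 2.0-fold higher number from compound 2 to compound 3 (0.31 log units; beyond the scatter), so this position can move the number beyond the scatter. With methoxy in place, fluoro in place of hydrogen on an aromatic carbon gives a 2.4-fold higher number from compound 1 to compound 3 (0.38 log units; beyond the scatter), a step that the close values of compound 1 and compound 2, which differ in two places, did not reveal. No available evidence explains either step. From the compounds shown here alone, it remains open whether an unfluorinated ethoxy group would behave like methoxy or like 2-fluoroethoxy, and how a longer chain or an amine would fare at this position.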